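Bromine position on the hydroxyphenyl amide

The source may report more compounds than this note shows. Statements on the series, on what has been measured and on what is new or still open speak of the compounds shown alone.

compound 1 `COc1c(Br)cccc1C(=O)Nc1ccc(Sc2nc3ccccc3s2)cc1`: > 100000 nM
compound 2 `O=C(Nc1ccc(Sc2nc3ccccc3s2)cc1)c1cccc(Br)c1O`: 26000 nM

In an assay for inhibition of HSP60/HSP10 (Homo sapiens), with a stated time of 60 min (a higher number here means a weaker inhibitor, a lower number a stronger inhibitor), compound 1 gives > 100000 nM, a limit of the assay rather than a number (the limit of > 100000 nM in this assay, at which 1 of the 2 values shown sits). For the measured compounds named here, compound 2 gives 26000 nM, the only number. Going by the values given here, the single measured step is an at least 3.8-fold lower number from compound 1 to compound 2 (0.58 log units; beyond the scatter), which changes the oxygen substituent and says nothing about where the bromine sits. Compound 3 `O=C(Nc1ccc(Sc2nc3ccccc3s2)cc1)c1cc(Br)ccc1O` differs from compound 2 by 5-bromo-2-hydroxyphenyl in place of 3-bromo-2-hydroxyphenyl on a carbonyl carbon. Among the compounds with values here, the only anchor for this change is compound 2 at 26000 nM. Compound 3 is therefore estimated at 26000 nM, between 8000 nM and 85000 nM. The expected step is no change at the digits printed from compound 2 to compound 3 (within the scatter), nothing beyond the scatter, with wide uncertainty.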

Compound 3, half-maximal inhibitory concentration: > 100000 nM
Compound 3: a limit, no number (the forecaster's own chance of this, stated with the estimate: 25%); middle value at least 3.8-fold (0.58 log units) from the limit.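

In this assay, moving the bromine gives an at least 3.8-fold higher number from compound 2 to compound 3 (0.58 log units; beyond the scatter), so 5-bromo-2-hydroxyphenyl on the carbonyl carbon does not match 3-bromo-2-hydroxyphenyl, although the two groups hold the same atoms. The result for compound 3 is a limit of the assay, not a number: the limit of > 100000 nM in this assay, at which 2 of the 3 values shown sit. The step between compound 1 and compound 3 cannot be read, as both results are limits.

Still open, from the compounds shown here alone, is whether a chlorine or an amine in place of the bromine of compound 2 would keep, lower or raise its number.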